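Swapping the ring on the carbonyl carbon of compound 3

The source may hold more compounds than are shown below. What is called first, only, known or untested is meant among the compounds shown, and "the series" means these compounds.

Of the compounds shown here, three sharing one core have been tested in a functional assay on MDA-MB-231 cells (Homo sapiens) for antiproliferative activity, read by XTT assay, with a stated time of 72 h; a lower number here means a stronger inhibitor, a higher number a weaker inhibitor. Compound 1 `COc1ccc(-c2cc3ccccc3nc2/C=C/C(=O)c2ccccc2)cc1` gives 860 nM. Compound 2 `COc1ccc(-c2cc3ccccc3nc2/C=C/C(=O)c2ccc(N)cc2)cc1` gives 7510 nM, and the step of an 8.7-fold higher number from compound 1 to compound 2 (0.94 log units; beyond the scatter) is the clearest worsening in the set. Compound 3 `COc1ccc(-c2cc3ccccc3nc2/C=C/C(=O)c2cccs2)cc1` gives 410 nM, the lowest of the three numbers: the step of a 2.1-fold lower number from compound 1 to compound 3 (0.32 log units; beyond the scatter) is modest, while an 18-fold lower number from compound 2 to compound 3 (1.26 log units; beyond the scatter) is large.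

Compound 4 `COc1ccc(-c2cc3ccccc3nc2/C=C/C(=O)c2c[nH]c3ccccc23)cc1` has not yet been measured. It differs from compound 3 only at the carbonyl carbon: 1H-indol-3-yl in place of thiophen-2-yl on a carbonyl carbon. Of the measured steps, only a 2.1-fold lower number from compound 1 to compound 3 (0.32 log units; beyond the scatter) and an 18-fold lower number from compound 2 to compound 3 (1.26 log units; beyond the scatter) change the group at that same place, and both describe the arrival of thiophen-2-yl, not its departure for a larger two-ring group carrying a hydrogen-bond donor. Among the compounds with values here, that leaves no direct precedent. Weighing the modest size of a 2.1-fold lower number from compound 1 to compound 3 (0.32 log units; beyond the scatter) against the worsening seen in an 8.7-fold higher number from compound 1 to compound 2 (0.94 log units; beyond the scatter), the number for compound 4 is estimated to move by a 2.0-fold higher number from compound 3 to compound 4 (0.29 log units; within the scatter). Compound 4 is expected to give about 800 nM, within a range of 250 nM to 2500 nM, in this assay.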

Compound 4, half-maximal inhibitory concentration: > 10000 nM
Compound 4: no number, only a limit (the forecaster's own chance of this, stated with the estimate: 3%); at least 12-fold (1.09 log units) between middle value and limit.
By their numbers in this assay, from the lowest: compound 3; then compound 1; then compound 2. At a limit, above all of these: compound 4.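

In this assay compound 4 reaches only a limit of the assay, > 10000 nM, not a measured number. The ring on the carbonyl carbon can therefore matter far more than the phenyl-to-thiophen-2-yl swap suggested: 1H-indol-3-yl brings an at least 24-fold higher number from compound 3 to compound 4 (1.38 log units; beyond the scatter) and an at least 11-fold higher number from compound 1 to compound 4 (1.06 log units; beyond the scatter), so an aromatic ring at this place is not enough to keep the activity. The step of an at least 1.3-fold higher number from compound 2 to compound 4 (0.12 log units; that floor lies within the scatter) is only a floor, too small to separate those two compounds, and all three steps rest on one limit: the limit of > 10000 nM in this assay, at which 1 of the 4 values shown sits.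

The compounds shown cannot separate the effect of the added six-membered ring from that of the hydrogen-bond donor, as both arrive together in 1H-indol-3-yl. As far as these compounds go, how a methyl group or a chlorine atom would read in place of the amino group of compound 2 also stays open.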